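A few compounds are considered here, and "the series" means these few. Any claim that something is new, unique, unknown or untested is made for them only; others in the source may bear on it.

Of the compounds shown here, two sharing one core have been tested so far. Compound 1 `Cc1ccc2nc(C(=O)Nc3c(F)cc(-c4cccc(F)c4)cc3F)c(C)c(O)c2c1` gives 11.2% in a functional assay on Hep 3B2 cells (Homo sapiens) for antiproliferative activity, read by MTT assay, with a stated time of 24 h, tested at 1.23 ug/mL (on this read-out higher numbers stand for a stronger effect at the one concentration tested and lower numbers for a weaker effect), a read-out that tells how strong the effect on cell growth was at the single concentration tested. Compound 2 `CCOc1ccc2nc(C(=O)Nc3c(F)cc(-c4cccc(F)c4)cc3F)c(C)c(O)c2c1` gives 1.03% in this assay. The only difference between them is an ethoxy in place of methyl on an aromatic carbon, and that change gave a number 10.2 percentage points lower from compound 1 to compound 2 (beyond the scatter), a modest fall that is nevertheless larger than the usual scatter. Within the data shown here, compound 2 therefore stands at the lower of the two numbers seen, with compound 1 the only neighbour.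

Compound 3 `Cc1c(C(=O)Nc2c(F)cc(-c3cccc(F)c3)cc2F)nc2ccc(OC(F)(F)F)cc2c1O` is the next one to be measured. It differs from compound 2 by trifluoromethyl in place of ethyl on an oxygen on an aromatic ring. Among the measured compounds shown here, no measured step covers this kind of change on an oxygen; the one step known concerns the aromatic carbon and was modest in size. Compound 3 is expected to give 5% in this assay, within a range from -10% to 20%. That estimate means an expected step of a number 4 percentage points higher from compound 2 to compound 3 (within the scatter), not beyond the scatter.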

Compound 3, a percentage reported as inhibition, at one concentration (the size of the read-out at that concentration, not a potency): 17.2%
Compound 3: the middle estimate sits 12.2 percentage points below what was measured; low and high end bracket the measured number.
By their numbers in this assay, from the lowest: compound 2; then compounds 1 and 3 (each within the scatter of the next).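

On an oxygen on an aromatic ring, the attached group clearly matters in this assay: trifluoromethyl in place of ethyl gives a number 16.2 percentage points higher from compound 2 to compound 3 (beyond the scatter) and so shows that the low reading of compound 2 does not extend to every group joined through this oxygen. Trifluoromethoxy in place of methyl on the aromatic carbon gives a number 6 percentage points higher from compound 1 to compound 3 (within the scatter) and so does not separate these two groups, which means that the drop seen with ethoxy is not a general result of putting an oxygen-linked group at this place. Nothing measured here explains why ethyl and trifluoromethyl on this oxygen give different readings.

The compounds shown leave open whether a methoxy, a longer chain such as propoxy, or an amine on this aromatic carbon would read like compound 2 or like compound 1 and compound 3. They also leave open how these compounds would compare at other concentrations, as each reading gives the size of the effect at a single concentration and is not a potency.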